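The source may hold more compounds than are shown below. What is called first, only, known or untested is meant among the compounds shown, and "the series" means these compounds.

Measured so far in a functional assay on L1210 cells (Mus musculus) for antiproliferative activity, with a stated time of 72 h; on this read-out lower numbers stand for an effect already at smaller amounts and higher numbers for an effect only at larger amounts of compound:
Compound 1 `Cc1cn([C@@H]2O[C@H](CO)[C@@H](CN=[N+]=[N-])[C@@H]2O)c(=O)[nH]c1=O`: 10 uM
Compound 2 `Cc1cn([C@@H]2O[C@H](CO)[C@@H](CO)[C@@H]2O)c(=O)[nH]c1=O`: > 100 uM

Compound 2 stands at the limit of > 100 uM in this assay, at which 1 of the 2 values shown sits, and this is a limit, not a number. Within the data shown here, the only measured step is an at least 10-fold higher number from compound 1 to compound 2 (1.00 log units; beyond the scatter). It puts hydroxy in place of azido on a saturated chain carbon, so it sets no size for a change on the ring.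

Compound 3 `Cc1cn([C@H]2C[C@H](CO)[C@@H](CO)O2)c(=O)[nH]c1=O` differs from compound 2 by hydrogen in place of hydroxy on a saturated ring carbon, with hydrogen in place of hydroxy on a saturated ring carbon. Among the measured compounds shown here, no measured step touches this carbon. Compound 3 keeps the hydroxy of that measured step, so no step beyond the scatter is expected in this assay, and another limit is likely. The expected change is a step that the limit leaves unreadable from compound 2 to compound 3. For compound 3 the estimate is 150 uM, with an expected range from 40 uM to 400 uM.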

Compound 3, concentration for half-maximal effect: 50 uM
Estimate against measurement, compound 3: 3.0-fold (0.48 log units) above; the measured number falls inside the stated range.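

Hydrogen in place of hydroxy on a saturated ring carbon gives the first reading for this position, and in this assay it appears as an at least 2.0-fold lower number from compound 2 to compound 3 (0.30 log units; that floor lies within the scatter). Compound 2 carries a limit and not a number: the limit of > 100 uM in this assay, at which 1 of the 3 values shown sits. The step therefore has only a floor, and since that floor lies within the scatter, the true size of the change cannot be read, although the compounds do show that a measured number in this assay does not depend on the hydroxy at this ring carbon.

The compounds shown leave open how an amine or a fluorine atom would read on this ring carbon. They also leave open whether azido in place of hydroxy on the chain carbon would give the same kind of step once the ring hydroxy is gone.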